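Series notes: ATM inhibition, chain variation at the aryl ether

The source may hold more compounds than are shown below. What is called first, only, known or untested is meant among the compounds shown, and "the series" means these compounds.

Measured compounds in an assay on MCF7 cells for inhibition of Serine-protein kinase ATM (Homo sapiens), read by immunofluorescence, with a stated time of 1 h; on this read-out higher numbers stand for weaker inhibition and lower numbers for stronger inhibition:
compound 1, `COCCOc1cc2ncnc(-n3nc(-c4ccccn4)nc3N)c2cc1OCCOC`: 2300 nM
compound 2, `COc1cc2ncnc(-n3nc(-c4ccc(C)cc4)cc3N)c2cc1OC`: > 40000 nM
compound 3, `COCCOc1cc2c(-n3nc(-c4ccccn4)nc3N)ncnc2cc1OC`: 1200 nM

The value of compound 2 is a limit of this assay, not a number. Of the two numbers shown, compound 3 and compound 1 sit within the scatter of each other, since a 1.9-fold lower number from compound 1 to compound 3 (0.28 log units; within the scatter). That step is the only measured one at this part of the shared core: it swaps hydrogen for methoxymethyl on a saturated chain carbon bound to an oxygen on an aromatic ring, and it moves the number by less than the scatter.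

Compound 4, `COc1cc2ncnc(-n3nc(-c4ccccn4)nc3N)c2cc1OCCCNC(=O)C(F)(F)F`, has not been measured. It differs from compound 3 by (((trifluoromethyl)carbonyl)amino)methyl in place of methoxy on a saturated chain carbon, two bonds along the chain from an oxygen on an aromatic ring. For the measured compounds named here, the one measured step at this position is small, so a change at the same chain is expected to stay within the scatter, though the entering group is larger than anything tested here and the expectation rests on one step alone. The estimate for compound 4 is 1500 nM, between 500 nM and 5000 nM, which is expected to mean a 1.3-fold higher number from compound 3 to compound 4 (0.10 log units; within the scatter).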

Compound 4, half-maximal inhibitory concentration: 2900 nM
Estimate against measurement, compound 4: 1.9-fold (0.29 log units) below, within the range that was stated.
By their numbers in this assay, from the lowest: compounds 3, 1 and 4 (each within the scatter of the next, the first and the last beyond it). At a limit, above all of these: compound 2.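

In this assay, replacing methoxy with (((trifluoromethyl)carbonyl)amino)methyl on a saturated chain carbon, two bonds along the chain from an oxygen on an aromatic ring, gives a 2.4-fold higher number from compound 3 to compound 4 (0.38 log units; beyond the scatter). This chain is therefore not indifferent to every change, which the earlier step could not show: a 1.9-fold lower number from compound 1 to compound 3 (0.28 log units; within the scatter). Still, the step is modest and compound 4 keeps a number rather than a limit, and nothing measured in these notes accounts for the shift.

Which part of the entering group carries the step remains open, whether the amide hydrogen, the carbonyl, the trifluoromethyl or the added length. Also open, from the compounds shown here alone, is how a free amine, a carboxylic acid or a longer chain at this place would read in this assay.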